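Aryl replacement at the shared core: compound 1 to compound 3

The compounds below may be only part of what the source reports. "The series", "measured", "known", "first", "only" and "open" are said of these compounds alone.

compound 1 `[O-][S+](Cc1ccccc1)c1nnc(-c2ccncc2)o1`: 3000 nM
compound 2 `COc1c(C)cnc(C[S+]([O-])c2nnc(-c3ccc(F)cc3)o2)c1C`: 11000 nM

In a functional assay on HUVEC cells (Homo sapiens) for inhibition, read by ELISA (on this read-out lower numbers stand for stronger inhibition and higher numbers for weaker inhibition), compound 1 gives 3000 nM, the lowest of the two numbers. Compound 2 gives 11000 nM, a gap beyond the scatter. Compound 3 `[O-][S+](Cc1ccccc1)c1nnc(-c2cccs2)o1` differs from compound 1 by thiophen-2-yl in place of pyridin-4-yl on an aromatic carbon. Among the compounds with values here, no measured pair isolates this change, so the expectation rests on compound 1 alone. The step of a 1.3-fold higher number from compound 1 to compound 3 (0.12 log units; within the scatter) is expected to be small, within the scatter or at most a slight move toward weaker inhibition. Compound 3 is estimated at 4000 nM, with a range from 1500 nM to 12000 nM.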

Compound 3, half-maximal inhibitory concentration: 6000 nM
Compound 3: the middle estimate sits 1.5-fold (0.18 log units) below what was measured, and the stated range covers the measured number.
By their numbers in this assay, from the lowest: compounds 1, 3 and 2 (each within the scatter of the next, the first and the last beyond it).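

The step of a 2.0-fold higher number from compound 1 to compound 3 (0.30 log units; within the scatter) in this assay shows that this aromatic carbon of the shared core accepts thiophen-2-yl in place of pyridin-4-yl with the two values staying within the scatter. The ring nitrogen of pyridin-4-yl is therefore not required to keep the number at this level, and a five-membered sulfur-containing ring serves as well. No available evidence explains this result. Still open, on these data alone, is how a simple phenyl ring or an aminomethyl-bearing aryl group would read at this carbon. Compound 2 differs from compound 1 in more than one place, so it does not settle this.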